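Chloro in place of hydrogen: lipophilicity notes on three compounds

This account rests on a few compounds, and the source may have more. Where it says the series, first, only, none or still open, it means among the compounds named here.

Measured so far:
compound 1, `Fc1ccccc1C1=NC(c2ccccc2)CO1`, 3.51
compound 2, `Clc1cccc(C2=NC(c3ccccc3)CO2)c1`, 4.44
compound 3, `Fc1cccc(Cl)c1C1=NC(c2ccccc2)CO1`, 3.45

In a physicochemical assay for lipophilicity (a lower number here means a more polar compound, a higher number a more lipophilic compound), compound 2 stands highest of the three; compound 1 lies well below it, and compound 3 lies furthest below, both gaps beyond the scatter. Compound 3 arises from compound 1 by chloro in place of hydrogen on an aromatic carbon, and this step gives a number 0.06 log units lower from compound 1 to compound 3 (within the scatter). How the core of compound 2 differs from that of compound 1 is not broken down here.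

Compound 4, `Clc1cccc(C2=NC(c3ccccc3)CO2)c1Cl`, is not yet measured. It arises from compound 2 by chloro in place of hydrogen on an aromatic carbon. The surroundings of the place are not the same as in the earlier pair: here the entering chloro group is ortho to a chloro group and ortho to a large group, whereas from compound 1 to compound 3 it was ortho to a large group and meta to a fluoro group. It is therefore the same kind of change, not the same change. Within the data shown here, the expectation rests on compound 1 and compound 3, whose step a number 0.06 log units lower from compound 1 to compound 3 (within the scatter) lay within the scatter; a comparably small step a number 0.06 log units higher from compound 2 to compound 4 (within the scatter) is expected, with widened bounds because only one earlier example exists. Compound 4 is estimated at 4.5, between 4.1 and 5.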

Compound 4, partition coefficient: 4.28
Beside the measured number, compound 4's estimate is 0.22 log units above it; the measured number falls inside the stated range.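

In this assay chloro in place of hydrogen on an aromatic carbon gives a number 0.16 log units lower from compound 2 to compound 4 (within the scatter) and gave a number 0.06 log units lower from compound 1 to compound 3 (within the scatter) on the other core, so in both pairs shown the step stays within the scatter. This rests on two pairs only, with different surroundings, the entering chloro group in compound 4 being ortho to a chloro group and ortho to a large group, and it does not show that the step stays this small on other cores or at other places on the ring. Nothing measured bears on why either step is this small.

The compounds shown leave open whether the step stays within the scatter when the shared core also carries an amine or a carboxylic acid. They also leave open whether a bromo group or a methoxy group in place of the entering chloro group would give a step of similar size.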